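Nitroarylidene cyclohexanone series: methoxy count on the aryl ring

This account rests on a few compounds, and the source may have more. Where it says the series, first, only, none or still open, it means among the compounds named here.

Measured compounds in a functional assay on HSC-3 cells (Homo sapiens) for cytotoxicity; a lower number here means that less compound is tolerated, a higher number that more compound is tolerated:
- compound 1, `COc1cc(/C=C2\CCC/C(=C\c3ccc([N+](=O)[O-])cc3)C2=O)ccc1O`: 5200 nM
- compound 2, `COc1ccc(/C=C2\CCC/C(=C\c3ccc([N+](=O)[O-])cc3)C2=O)cc1OC`: 4400 nM

For the measured compounds named here, compound 2 gives the lower of the two numbers in this assay, but its nearest neighbour is compound 1, and the only measured step, a 1.2-fold lower number from compound 1 to compound 2 (0.07 log units; within the scatter), lies within the scatter. On the numbers shown, compound 2 and compound 1 are therefore not separated.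

Compound 3, `COc1cc(/C=C2\CCC/C(=C\c3ccc([N+](=O)[O-])cc3)C2=O)cc(OC)c1OC`, is not yet measured. It differs from compound 2 by methoxy in place of hydrogen on an aromatic carbon. Going by the values given here, the one measured step that bears on this change is the methylation of the ring oxygen, a 1.2-fold lower number from compound 1 to compound 2 (0.07 log units; within the scatter), which did not move the number beyond the scatter. Adding a further methoxy to the same ring is expected to behave alike, so no step beyond the scatter is expected in this assay, no change at the digits printed from compound 2 to compound 3 (within the scatter).

Compound 3 is thus estimated at 4400 nM, with a plausible range from 2000 nM to 10000 nM.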

Compound 3, half-maximal cytotoxic concentration: 4700 nM
Compound 3: the middle estimate sits 1.1-fold (0.03 log units) below what was measured; measured number inside the range.
By their numbers in this assay, from the lowest: compounds 2, 3 and 1 (each within the scatter of the next).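

In this assay the added methoxy, on an aromatic carbon ortho to a methoxy group and meta to a large group, gives a 1.1-fold higher number from compound 2 to compound 3 (0.03 log units; within the scatter) and so leaves hydrogen and methoxy at this position unseparated. This is the first change shown on a ring carbon rather than on a ring oxygen, and like the earlier change on oxygen it stays within the scatter, so neither kind of methoxy change has yet moved the number in this series. No measurement at hand bears on why the number holds here.

As far as these compounds go, whether this aromatic carbon responds to anything other than methoxy remains open, for instance an amine, a carboxylic acid or a longer chain such as butoxy. All three compounds also share the nitro group on the other aryl ring, so its contribution cannot be read from them.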